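This account rests on a few compounds, and the source may have more. Where it says the series, first, only, none or still open, it means among the compounds named here.

Measured compounds in the series so far:

- compound 1, `COc1ccc(-c2cc3ccccc3nc2/C=C/C(=O)c2ccc(N)cc2)cc1`, 7400 nM
- compound 2, `COc1ccc(-c2cc3ccccc3nc2/C=C/C(=O)c2ccccn2)cc1`, 6260 nM

Both numbers come from a functional assay on NCI-H460 cells (Homo sapiens) for antiproliferative activity, read by XTT assay, with a stated time of 72 h; on this read-out lower numbers stand for stronger inhibition and higher numbers for weaker inhibition. Compound 2 sits at the low end of the two, but the step of a 1.2-fold lower number from compound 1 to compound 2 (0.07 log units; within the scatter) is within the scatter, so compound 2 and compound 1 are not distinguished on these data; there is no sign that the group on the carbonyl carbon has moved the read-out at all.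

Compound 3, `COc1ccc(-c2cc3ccccc3nc2/C=C/C(=O)c2sccc2N)cc1`, is the next unmeasured member. It differs from compound 2 in one place: 3-aminothiophen-2-yl in place of pyridin-2-yl on a carbonyl carbon.

Among the measured compounds shown here, the only measured step that bears on this change is the swap at the same carbonyl carbon, from compound 1 to compound 2, which came out within the scatter. On that basis the expected step of a 1.1-fold lower number from compound 2 to compound 3 (0.06 log units; within the scatter) is none beyond the scatter, in no particular direction; a single prior swap at this position gives no ground for a larger shift. Compound 3 is therefore estimated at 5500 nM in this assay, with a range of 2000 nM to 15000 nM.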

Compound 3, half-maximal inhibitory concentration: > 10000 nM
Compound 3 was reported as a limit (the forecaster's own chance of this, stated with the estimate: 5%); middle value at least 1.8-fold (0.25 log units) away from the limit.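

In this assay, compound 3 is reported only as a limit and not as a number: the limit of > 10000 nM in this assay, at which 1 of the 3 values shown sits.

At this carbonyl carbon the change gives an at least 1.5-fold higher number from compound 2 to compound 3 (0.20 log units; that floor lies within the scatter), and the comparison with the 4-aminophenyl group gives an at least 1.3-fold higher number from compound 1 to compound 3 (0.13 log units; that floor lies within the scatter). Neither floor separates compound 3 from compound 2 or compound 1, but the limit does allow only one direction, toward weaker inhibition, whereas the earlier swap at this position showed no direction at all.

The compounds shown do not tell whether this direction goes with the five-membered sulfur-containing ring or with the amine on it, and compound 1 carries an amine as well; a plain thiophen-2-yl group or a 3-aminopyridin-2-yl group on the same carbonyl carbon would pull those two features apart. From the compounds shown here alone, the true size of both steps also stays open for as long as compound 3 stands as a limit.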